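This account rests on a few compounds, and the source may have more. Where it says the series, first, only, none or still open, it means among the compounds named here.

- Compound 1 `CCCC(CC)C(=O)NOC`: 142 mg/kg
- Compound 2 `CN(C)c1ccc(/C=N/Nc2nnc(-c3ccccc3)nc2Cc2cccc(Cl)c2)cc1`: 54.3 mg/kg

In a functional assay on the whole organism (strain Albino) with Mus musculus as the target, in the maximal electroshock model (on this read-out higher numbers stand for an effect only at larger amounts of compound and lower numbers for an effect already at smaller amounts), compound 2 has the lower of the two numbers at 54.3 mg/kg, and the gap to compound 1 at 142 mg/kg lies beyond the scatter. Compound 3 `CN(C)c1ccc(/C=N/Nc2nnc(-c3ccccc3)nc2Cc2ccc(Cl)cc2)cc1` has 4-chlorophenyl in place of 3-chlorophenyl, on a saturated chain carbon bound to an aromatic carbon (4-chlorophenyl in place of 3-chlorophenyl on a saturated chain carbon bound to an aromatic carbon). Among the compounds with values here, no measured pair of compounds shows what a change of this kind does, so no shift beyond the scatter is expected in this assay. The expected step is small: a 1.1-fold higher number from compound 2 to compound 3 (0.04 log units; within the scatter). The estimate for compound 3 is 60 mg/kg, with an expected range of 28 mg/kg to 130 mg/kg.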

Compound 3, dose for half-maximal effect: 46.1 mg/kg
Compound 3: middle estimate off by 1.3-fold (0.11 log units), on the high side; the measured number falls inside the stated range.
By their numbers in this assay, from the lowest: compounds 3 and 2 (each within the scatter of the next); then compound 1.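

In this assay, 4-chlorophenyl in place of 3-chlorophenyl gives a 1.2-fold lower number from compound 2 to compound 3 (0.07 log units; within the scatter) and so leaves the number inside the scatter. On a saturated chain carbon bound to an aromatic carbon, this exchange between two chlorophenyl groups therefore produces no readable change in the mouse test. Nothing available explains why the two compounds behave alike. From the compounds shown here alone, it remains open whether plain phenyl or 4-methoxyphenyl at this place would shift the number beyond the scatter. A single pair also cannot show whether the same exchange behaves alike on other cores.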